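The source may report more compounds than this note shows. Statements on the series, on what has been measured and on what is new or still open speak of the compounds shown alone.

In a functional assay on COR-L23 cells (Homo sapiens) for antiproliferative activity, read by CellTiter-Glo, with a stated time of 72 h (a higher number here means a weaker inhibitor, a lower number a stronger inhibitor), compound 1 `C[C@H](NC(=O)[C@@H]1CCCN1C)c1ccc(NC(=O)N2CC(c3ccc(N)nc3)C2)cc1` gives 41 nM and compound 2 `CCC(=O)N[C@@H](C)c1ccc(NC(=O)N2CC(c3ccc(N)nc3)C2)cc1` gives 120 nM, the higher of the two numbers. Compound 3 `CCC(=O)N[C@@H](C)c1ccc(NC(=O)N2CC(c3cncc(N)c3)C2)cc1` carries 5-aminopyridin-3-yl in place of 6-aminopyridin-3-yl on a saturated ring carbon. For the measured compounds named here, the only measured step, a 2.9-fold higher number from compound 1 to compound 2 (0.47 log units; beyond the scatter), is modest and lies elsewhere, on a carbonyl carbon, so it offers a sense of scale but no direct precedent. Going by the values given here, no measured compound carries 5-aminopyridin-3-yl. A modest rise in this assay is expected, as a 2.5-fold higher number from compound 2 to compound 3 (0.40 log units; beyond the scatter), though the direction is uncertain. For compound 3 the estimate is 300 nM, with an expected range of 50 nM to 1500 nM.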

Compound 3, half-maximal inhibitory concentration: 1580 nM
Compound 3: middle estimate off by 5.3-fold (0.72 log units), on the low side; the whole stated range lies below it.
By their numbers in this assay, from the lowest: compound 1; then compound 2; then compound 3.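

In this assay, the two aminopyridines are not interchangeable on this saturated ring carbon: 5-aminopyridin-3-yl in place of 6-aminopyridin-3-yl is a large step (a 13-fold higher number from compound 2 to compound 3 (1.12 log units; beyond the scatter)), although the two groups have the same atom, donor and acceptor counts. The modest step on the carbonyl carbon (a 2.9-fold higher number from compound 1 to compound 2 (0.47 log units; beyond the scatter)) is smaller. Nothing at hand explains the rise. Open, on these data alone, is how unsubstituted pyridin-3-yl or 6-(methylamino)pyridin-3-yl would compare with compound 2, and whether 5-aminopyridin-3-yl would have the same effect with the 1-methylpyrrolidin-2-yl group of compound 1.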